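The source may hold more compounds than are shown below. What is called first, only, known or untested is meant among the compounds shown, and "the series" means these compounds.

Compound 1 `CCOC(=O)Cn1cc(CNC(=O)c2cn(CC(=O)OCc3ccccc3)nn2)nn1` and compound 2 `CC(=O)OCCn1cc(CNC(=O)c2cn(CC(=O)OCc3ccccc3)nn2)nn1` share a core, and in a functional assay on B16 cells (Mus musculus) for cytotoxicity, read by MTT assay, with a stated time of 48 h (a lower number here means a stronger inhibitor, a higher number a weaker inhibitor), compound 1 reports only the limit > 100000 nM. Compound 2 likewise reaches only the limit > 100000 nM in this assay. The change between them, (acetoxymethyl in place of ethoxycarbonyl on a saturated chain carbon bound to an aromatic nitrogen), therefore gives a step that the two limits leave unreadable from compound 1 to compound 2, since both values sit at the limit of > 100000 nM in this assay, at which 2 of the 3 values shown sit. Compound 3 `CCOC(=O)Cn1cc(C(=O)Nc2cccc(-c3cn(Cc4ccccc4)nn3)c2)nn1` carries a different core, and the difference between the two cores is not broken down here; in this assay compound 3 gives 20400 nM. Compound 4 `CC(=O)OCCn1cc(C(=O)Nc2cccc(-c3cn(Cc4ccccc4)nn3)c2)nn1` differs from compound 3 by acetoxymethyl in place of ethoxycarbonyl on a saturated chain carbon bound to an aromatic nitrogen, the same change as from compound 1 to compound 2, at the same place. Because that earlier step is a step that the two limits leave unreadable from compound 1 to compound 2, the change offers no readable direction, and a step of about a 1.0-fold lower number from compound 3 to compound 4 (0.01 log units; within the scatter) is expected. Compound 4 is thus estimated at 20000 nM, likely between 7000 nM and 60000 nM.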

Compound 4, half-maximal inhibitory concentration: > 100000 nM
Compound 4: no number, only a limit (the forecaster's own chance of this, stated with the estimate: 15%); middle value at least 5.0-fold (0.69 log units) away from the limit.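

On these data alone, on the core of compound 3, acetoxymethyl in place of ethoxycarbonyl gives an at least 4.9-fold higher number from compound 3 to compound 4 (0.69 log units; beyond the scatter) in this assay, and compound 4 reports only a limit, so the true size of this step stays unknown. The same change from compound 1 to compound 2 cannot be read, so the series does not show whether the change acts alike on both cores, only that the loss appears on the core of compound 3. Most of the series gives no number to compare: the limit of > 100000 nM in this assay, at which 3 of the 4 values shown sit.

As far as these compounds go, it remains open how a free carboxylic acid, an amine or a longer chain at this place would read on the core of compound 3. From the compounds shown here alone, it also remains open whether any such group would give a readable number on the core of compound 1.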